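The source may hold more compounds than are shown below. What is called first, only, known or untested is meant among the compounds shown, and "the series" means these compounds.

Working notes on the series.

Three compounds carry measured numbers in an assay for inhibition of 15-hydroxyprostaglandin dehydrogenase [NAD(+)] (Homo sapiens), read by fluorescence, with a stated time of 15 min, in the presence of a further agent that is not named here; on this read-out lower numbers stand for stronger inhibition and higher numbers for weaker inhibition. Compound 1 `CCCC[S+]([O-])c1sc2nc(-c3nccs3)cc(-c3ccc(COC(=O)CN(C)C)cc3)c2c1N` gives 3.5 nM. Compound 3 `CCCC[S+]([O-])c1sc2nc(-c3nc(C)cs3)cc(-c3cnc(C)n3C)c2c1N` gives 2.8 nM, and compound 2 `CCCC[S+]([O-])c1cc2c(-c3ccccc3)nc(-c3ccccc3)nc2s1` gives 93 nM. Compound 1 stands second highest of the three: compound 3 lies within the scatter of it, so the two cannot be ordered, while compound 2 sits beyond the scatter with the clearly higher number. No pair among these three differs in a single place, so no measured single step is available.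

The next compound, compound 4 `CCCC[S+]([O-])c1sc2nc(-c3nccs3)cc(-c3ccc(C(=O)OC)cc3)c2c1N`, differs from compound 1 in one place: methoxycarbonyl in place of ((((dimethylamino)methyl)carbonyl)oxy)methyl on an aromatic carbon, para to a large group. Going by the values given here, with no measured step of this kind to lean on, the expectation for this assay is a step of modest size at most, in either direction, most likely none beyond the scatter, since the shared core and the remaining substituents of compound 1 are kept. Compound 4 is therefore expected near 5 nM, in the range 1.5 nM to 15 nM, which corresponds to an estimated step of a 1.4-fold higher number from compound 1 to compound 4 (0.15 log units; within the scatter).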

Compound 4, half-maximal inhibitory concentration: 15.1 nM
The estimate for compound 4 lay 3.0-fold (0.48 log units) below the measured number; measured number above the stated range.
By their numbers in this assay, from the lowest: compounds 3 and 1 (each within the scatter of the next); then compound 4; then compound 2.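

Going by these compounds alone, this is the only measured single step: in this assay, methoxycarbonyl in place of ((((dimethylamino)methyl)carbonyl)oxy)methyl gives a 4.3-fold higher number from compound 1 to compound 4 (0.63 log units; beyond the scatter), a step beyond the scatter. The number therefore responds to the group on this aromatic carbon, para to a large group, even with the rest of compound 1 kept. Nothing measured here bears on the reason for this step.

The change shortens the group from 8 heavy atoms to 4 and removes its nitrogen in the same step, so the two differences cannot be separated. Open too, going by these compounds, is how the number would respond at this place to a hydroxymethyl group, a carboxylic acid or a dimethylaminomethyl group, and whether this step would carry over to another core.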